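Swapping Trifluoromethyl for Methylsulfanyl on the Aryl Ring

A few compounds are considered here, and "the series" means these few. Any claim that something is new, unique, unknown or untested is made for them only; others in the source may bear on it.

The series here was tested in a functional assay on RKE cells for antagonist activity at Vasoactive intestinal polypeptide receptor 1 (Rattus norvegicus), read by HTRF and cAMP accumulation, with stated times of 10 min and 30 min; on this read-out higher numbers stand for weaker inhibition and lower numbers for stronger inhibition. Compound 1 `CC(C)c1cc(C(C)(C)C)cc(-c2ccc(F)cc2)c1CO` gives 740 nM in this assay. Compound 2 `CCC(=O)Nc1sc2c(c1C#N)CCCC2`, built on a different core, gives 12000 nM. Compound 3 `CC(C)c1cc(C(C)(C)C)cc(-c2cccc(C(F)(F)F)c2)c1CO` reaches only the limit of this assay, > 50000 nM, so no number is known for it, only that it lies at the edge of what the assay can report; this is the limit of > 50000 nM in this assay, at which 1 of the 3 values shown sits. Compound 3 therefore stands apart from the two compounds that gave numbers.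

Compound 4 `CSc1cccc(-c2cc(C(C)(C)C)cc(C(C)C)c2CO)c1` is the next variation on the shared core of compound 1 and compound 3. Its change from compound 3 is methylsulfanyl in place of trifluoromethyl on an aromatic carbon. Among the compounds with values here, because compound 3 sits at > 50000 nM, the starting point of this step is itself unknown, and no measured pair shows how the change behaves. The expectation for compound 4 is a step of an at least 2.0-fold lower number from compound 3 to compound 4 (0.30 log units; that floor lies within the scatter), with a real risk that the assay again reports only a limit. The estimate for compound 4 in this assay is 25000 nM, within a range from 4000 nM to 50000 nM.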

Compound 4, half-maximal inhibitory concentration: 170 nM
Compound 4: the middle estimate sits 150-fold (2.17 log units) above what was measured; the whole stated range lies above it.
By their numbers in this assay, from the lowest: compound 4; then compound 1; then compound 2. At a limit, above all of these: compound 3.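

The earlier compounds shown here gave no number for any group on this aromatic carbon of the aryl ring that could be set against another, and compound 4 now supplies one: in this assay compound 4 gives 170 nM. Methylsulfanyl in place of trifluoromethyl brings an at least 290-fold lower number from compound 3 to compound 4 (2.46 log units; beyond the scatter), a large change from swapping one small group on the shared core. That size is only a floor, because the value for compound 3 is a limit and not a number: the limit of > 50000 nM in this assay, at which 1 of the 4 values shown sits.

A single pair cannot show which difference between the two groups matters, whether the sulfur, the loss of fluorine or the lower count of heavy atoms. On these data alone, how a methoxy group, an amine or a longer thioether chain would behave on this same aromatic carbon remains open.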